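From methyl to trifluoromethyl: compound 2 to compound 4

A few compounds are considered here, and "the series" means these few. Any claim that something is new, unique, unknown or untested is made for them only; others in the source may bear on it.

In an ADME assay on HepG2 cells (Homo sapiens) for cytotoxicity, read by XTT assay, with a stated time of 2 days (a lower number here means that less compound is tolerated, a higher number that more compound is tolerated), compound 2 `Cc1cc(NC(=O)c2sc(N)c(C(N)=O)c2C)ccc1Cl` gives > 100000 nM and this is a limit of the assay, not a number. Among the compounds with values here, compound 3 `Cc1cc(NC(=O)c2sc(N)c(C(N)=O)c2C)ccc1Br` gives 107000 nM as the only number in hand. For compound 1 `NC(=O)c1c(N)sc2c1CCCN2C(=O)c1ccccc1` the entry reads "not determined" (no result reported) and offers no guide. Within the data shown here, the one measured step that the limit leaves unreadable from compound 2 to compound 3 is bromo in place of chloro on an aromatic carbon and has no readable size. Compound 4 `Cc1c(C(=O)Nc2ccc(Cl)c(C(F)(F)F)c2)sc(N)c1C(N)=O` differs from compound 2 by trifluoromethyl in place of methyl on an aromatic carbon in the form of trifluoromethyl in place of methyl on an aromatic carbon, ortho to a chloro group. Among the measured compounds shown here, with compound 3 at 107000 nM as the only guide, no shift beyond the scatter is expected in this assay from this change. The expected step of an at least 1.1-fold lower number from compound 2 to compound 4 (0.04 log units; that floor lies within the scatter) has no firm direction. For compound 4 the estimate is 90000 nM with an expected range of 40000 nM to 180000 nM around it.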

Compound 4, half-maximal cytotoxic concentration: 72000 nM
Beside the measured number, compound 4's estimate is 1.3-fold (0.10 log units) above it; measured number inside the range.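

In this assay, the position ortho to a chloro group now has a step with a lower bound: trifluoromethyl in place of methyl gives an at least 1.3-fold lower number from compound 2 to compound 4 (0.14 log units; that floor lies within the scatter). That floor lies within the usual scatter, so the change shows no firm shift at this position, although the true step could be larger. Its full size stays unknown because compound 2 stands at a limit of the assay: the limit of > 100000 nM in this assay, at which 1 of the 4 values shown sits.

Still open, from the compounds shown here alone, is how an amine or a carboxylic acid at this position would behave, and whether the step holds with bromo in place of the chloro group.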